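A few compounds are considered here, and "the series" means these few. Any claim that something is new, unique, unknown or untested is made for them only; others in the source may bear on it.

The series shares one core, seen in compound 3 `Oc1ccccc1/C=N/c1ccc(OCc2ccccc2)cc1`. In a functional assay, with a stated time of 30 min (on this read-out lower numbers stand for stronger inhibition and higher numbers for weaker inhibition), compound 3 gives only a limit, > 200000 nM. Compound 1 `Cc1cccc(/C=N/c2ccc(OCc3ccccc3)cc2)c1O` carries a methyl on the phenol ring; in this assay compound 1 likewise gives only a limit, > 200000 nM. Compound 2 `O=[N+]([O-])c1ccc(O)c(/C=N/c2ccc(OCc3ccccc3)cc2)c1` carries a nitro group on that ring; in this assay compound 2 also gives only a limit, > 200000 nM. All three values sit at the same limit (the limit of > 200000 nM in this assay, at which 3 of the 3 values shown sit), so none of the three can be set apart from the others on the numbers shown.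

The change to compound 4 `Cc1ccc(O)c(/C=N/c2ccc(OCc3ccccc3)cc2)c1` is methyl in place of hydrogen on an aromatic carbon, that is, 2-hydroxyphenyl to 2-hydroxy-5-methylphenyl. Within the data shown here, two measured steps touch substitution of this ring: a step that the two limits leave unreadable from compound 1 to compound 3 and a step that the two limits leave unreadable from compound 2 to compound 3. Neither can be read, as both ends sit at the limit. Nothing measured shows a small group on this ring moving the read-out off the limit; the methyl of compound 1 stayed there. The step of a number no higher from compound 3 to compound 4 (the limit leaves the size open) is therefore expected to stay within the scatter. The estimate for compound 4 is 200000 nM, with a range from 100000 nM to 400000 nM, and another limit is the most likely outcome.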

Compound 4, half-maximal inhibitory concentration: > 200000 nM
Compound 4 ended at the assay's limit (the forecaster's own chance of this, stated with the estimate: 85%); the middle value lies on the limit itself.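

The steps among compound 1, compound 2, compound 3 and compound 4 cannot be read, because all four values are limits: the limit of > 200000 nM in this assay, at which 4 of the 4 values shown sit.

The compounds shown leave open whether any substituent on the hydroxy-bearing ring of the shared core can bring the read-out off this limit, and how large any differences among these four compounds are.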